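The source may hold more compounds than are shown below. What is called first, only, known or untested is meant among the compounds shown, and "the series" means these compounds.

Measured in a functional assay on HepG2 cells (Homo sapiens) for cytotoxicity, read by MTT assay, with a stated time of 24 h; a higher number here means a weaker inhibitor, a lower number a stronger inhibitor:

compound 1, `COc1cc(/C=C2\CN(C)C/C(=C\c3ccc(Cl)cc3)C2=O)cc(OC)c1`, gives 5950 nM
compound 2, `COc1cc(/C=C2\CN(C)C/C(=C\c3ccc(Br)cc3)C2=O)cc(OC)c1`, gives 4840 nM
compound 3, `CN1C/C(=C\c2ccc(Cl)cc2)C(=O)/C(=C/c2ccc(C#N)cc2)C1`, gives 5950 nM

Compound 4, `CN1C/C(=C\c2ccc(Br)cc2)C(=O)/C(=C/c2ccc(C#N)cc2)C1`, is not yet measured. Compound 3 and compound 1 give the same number at the digits shown, and compound 2 lies within the scatter of both; no order among the three is claimed.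

The change from compound 3 to compound 4 is bromo in place of chloro on an aromatic carbon. The same change is already measured once, from compound 1 to compound 2, where it reads bromo in place of chloro on an aromatic carbon and made a 1.2-fold lower number from compound 1 to compound 2 (0.09 log units; within the scatter). Both changes sit at the same place word for word, so this is the same change on a different core; the difference between the two cores is not broken down here.

For compound 4 in this assay a step of a 1.2-fold lower number from compound 3 to compound 4 (0.08 log units; within the scatter) is expected, resting on compound 1 and compound 2 because a 1.2-fold lower number from compound 1 to compound 2 (0.09 log units; within the scatter) was within the scatter. The estimate for compound 4 is 5000 nM, with a likely range from 2500 nM to 10000 nM.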

Compound 4, half-maximal inhibitory concentration: 4840 nM
Compound 4: the middle estimate sits 1.0-fold (0.01 log units) above what was measured; the measured number falls inside the stated range.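

In this assay, bromo in place of chloro on an aromatic carbon gives a 1.2-fold lower number from compound 3 to compound 4 (0.09 log units; within the scatter), and this step agrees with the one on the core of compound 1: the same change on two cores in this assay, a 1.2-fold lower number (0.09 log units; within the scatter) from compound 1 to compound 2 and a 1.2-fold lower number (0.09 log units; within the scatter) from compound 3 to compound 4, 1.0-fold (0.00 log units) apart, within the scatter of two such steps

The change therefore reads alike on these two cores, but both steps lie within the scatter, so the agreement is between two steps that are not distinguishable from no change. It does not show that a step beyond the scatter would carry between these cores, and two cores support no rule beyond compounds 1 to 4.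

Still open, going by these compounds, is whether an amine or a carboxylic acid on that aromatic carbon, in place of the halogen, would give a step beyond the scatter on either core.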